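Carboxymethyl on the Ring Nitrogen of a Weak Core

The source may report more compounds than this note shows. Statements on the series, on what has been measured and on what is new or still open speak of the compounds shown alone.

Compound 1 `O=C1NC(=S)S/C1=C\C1=Cc2ccccc2OC1`: 55300 nM
Compound 2 `CN1C(=N)NC(=O)/C1=C/C1=Cc2ccccc2OC1`: 96500 nM
Compound 3 `CN1C(=O)S/C(=C\C2=Cc3ccccc3OC2)C1=O`: > 100000 nM, a limit of the assay

Of the compounds shown here, three that share the same core have been tested in a functional assay on K562 cells (Homo sapiens) for antiproliferative activity, read by MTT assay, with a stated time of 72 h; on this read-out higher numbers stand for weaker inhibition and lower numbers for stronger inhibition. Compound 1 gives 55300 nM, the lower of the two actual numbers. Compound 2 gives 96500 nM, and the gap between compound 2 and compound 1 lies within the usual scatter, so the two cannot be told apart. Compound 3 gives only a limit and not a number; it sits at the limit of > 100000 nM in this assay, at which 1 of the 3 values shown sits. All three are weak on this read-out.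

Compound 4 `O=C(O)CN1C(=O)/C(=C/C2=Cc3ccccc3OC2)SC1=S` has not yet been measured in this assay. It is compound 1 with one change: carboxymethyl in place of hydrogen on an amide-type nitrogen in a ring. Within the data shown here, no pair of measured compounds shows what such an exchange does here, so the step has to be guessed. A modest shift in either direction, or none beyond the scatter, is the expectation.

Compound 4 is therefore expected to give about 45000 nM, with a likely range from 15000 nM to 100000 nM. That estimate means a step of a 1.2-fold lower number from compound 1 to compound 4 (0.09 log units; within the scatter), close to the scatter itself.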

Compound 4, half-maximal inhibitory concentration: > 100000 nM
Compound 4: only a limit was reported; the forecaster's own chance of this, stated with the estimate: 25%; at least 2.2-fold (0.34 log units) between middle value and limit.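

Placing carboxymethyl in place of hydrogen on an amide-type nitrogen in a ring gives the first readable step at this position in this assay: an at least 1.8-fold higher number from compound 1 to compound 4 (0.25 log units; that floor lies within the scatter). Higher numbers stand for weaker inhibition here, so this exchange gives no sign of stronger inhibition, although the printed floor alone does not separate the step from ordinary scatter. The value of compound 4 is a limit and not a number, so the step has a floor but no upper end, and its true size stays unknown: the limit of > 100000 nM in this assay, at which 2 of the 4 values shown sit.

The compounds shown leave open how much of this result belongs to the carboxylic acid at the end of the new chain and how much to the presence of any chain on this nitrogen. An ethyl group, a methyl ester of the same chain or a longer chain ending in an amine, each placed on this nitrogen of the core of compound 1, would help to separate those two readings.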